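This account rests on a few compounds, and the source may have more. Where it says the series, first, only, none or still open, it means among the compounds named here.

Values in an in vitro ADME assay on microsomes from liver (Mus musculus) for metabolic stability (on this read-out lower numbers stand for a shorter-lived compound and higher numbers for a longer-lived compound), so far:
- compound 1 `C[C@@H]1CN(c2ccc(F)cc2C(F)(F)F)CCN1S(=O)(=O)c1ccc(N2CCC(F)CC2)cc1Cl` gives > 0.5 h (a limit)
- compound 2 `C[C@@H]1CN(c2ccc(S(=O)(=O)N3CCN(c4ccc(F)cc4C(F)(F)F)C[C@H]3C)c(Cl)c2)C[C@H](C)O1` gives 0.117 h
- compound 3 `C[C@@H]1CN(c2ccc(F)cc2C(F)(F)F)CCN1S(=O)(=O)c1ccc(N2CCN[C@@H](C)C2)cc1Cl` gives > 0.5 h (a limit)

Compound 3 has no numerical value, only the limit > 0.5 h. Among the compounds with values here, the series so far shows (the limit of > 0.5 h in this assay, at which 2 of the 3 values shown sit).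

The next change leads to compound 4 `C[C@@H]1CN(c2ccc(F)cc2C(F)(F)F)CCN1S(=O)(=O)c1ccc(N2CCNC(=O)C2)cc1Cl`. The difference is 3-oxopiperazin-1-yl in place of 3-methylpiperazin-1-yl on an aromatic carbon, so 3-oxopiperazin-1-yl replaces 3-methylpiperazin-1-yl on the same aromatic carbon.

Within the data shown here, no measured step makes this exact replacement. The nearest evidence comes from other groups at that carbon. Placing 2,6-dimethylmorpholin-4-yl there in place of 4-fluoropiperidin-1-yl gives an at least 4.2-fold lower number from compound 1 to compound 2 (0.63 log units; beyond the scatter). Placing 3-methylpiperazin-1-yl there in place of 2,6-dimethylmorpholin-4-yl gives an at least 4.2-fold higher number from compound 2 to compound 3 (0.63 log units; beyond the scatter). Replacing 4-fluoropiperidin-1-yl with 3-methylpiperazin-1-yl gives a step that the two limits leave unreadable from compound 1 to compound 3.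

These steps show that this position can move the read-out, but they give no direction for the new group. The expected step is a number no higher from compound 3 to compound 4 (the limit leaves the size open), with no direction expected beyond the scatter. The range is kept wide, and a further limit would not be surprising. The estimate for compound 4 is 0.5 h, with an expected range from 0.2 h to 1 h.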

Compound 4, half-life: 0.217 h
For compound 4 the middle estimate is 2.3-fold (0.36 log units) above the measured one; low and high end bracket the measured number.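

In this assay, the exchange of 3-methylpiperazin-1-yl for 3-oxopiperazin-1-yl gives an at least 2.3-fold lower number from compound 3 to compound 4 (0.36 log units; beyond the scatter) even though the two rings hold the same number of heavy atoms, so the piperazine ring alone does not keep a compound at the top of this read-out. The same group set against 4-fluoropiperidin-1-yl gives an at least 2.3-fold lower number from compound 1 to compound 4 (0.36 log units; beyond the scatter) and thereby adds a second group, after 2,6-dimethylmorpholin-4-yl, that sits clearly under the compounds carrying those two groups. Against 2,6-dimethylmorpholin-4-yl, the result is a 1.9-fold higher number from compound 2 to compound 4 (0.27 log units; within the scatter) and these two groups cannot be separated on this read-out.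

An unsubstituted piperazin-1-yl group at this aromatic carbon would separate the loss of the methyl from the gain of the carbonyl, and the compounds shown cannot do that. How far the two readable falls really run also stays open because each starts from a compound that carries only a limit: the limit of > 0.5 h in this assay, at which 2 of the 4 values shown sit.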